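This account rests on a few compounds, and the source may have more. Where it says the series, first, only, none or still open, it means among the compounds named here.

Measured so far:
compound 1 `c1cc([C@H]2CC[C@]3(CC2)OOC2(O3)C3CC4CC(C3)CC2C4)ccc1OC1CCNCC1`: > 100 ug/mL (a limit of the assay)
compound 2 `NC1CCN(S(=O)(=O)c2ccc([C@H]3CC[C@]4(CC3)OOC3(O4)C4CC5CC(C4)CC3C5)cc2)CC1`: 12.5 ug/mL

In a physicochemical assay for solubility, read by nephelometry, measured as kinetic solubility, with a stated time of 30 min (a lower number here means a less soluble compound, a higher number a more soluble compound), compound 2 gives 12.5 ug/mL as the only actual number shown. Compound 1 stands at > 100 ug/mL as a limit of the assay, not a number.

The change to compound 3 `NCCCCOc1ccc([C@H]2CC[C@]3(CC2)OOC2(O3)C3CC4CC(C3)CC2C4)cc1` is 4-aminobutoxy in place of (4-aminopiperidin-1-yl)sulfonyl on an aromatic carbon and puts 4-aminobutoxy in place of (4-aminopiperidin-1-yl)sulfonyl on an aromatic carbon, para to a large group. Going by the values given here, one measured step bears on it, an at least 8.0-fold lower number from compound 1 to compound 2 (0.90 log units; beyond the scatter) on going from (piperidin-4-yl)oxy to (4-aminopiperidin-1-yl)sulfonyl. Compound 3 loses that sulfonyl group and, as in compound 1, its side group is joined through oxygen, so the new change runs against that step. This is a single step with one end at a limit, and no open-chain group has been measured, so it is only a rough guide. The step expected in this assay is a 4.0-fold higher number from compound 2 to compound 3 (0.60 log units; beyond the scatter) towards a higher number. For compound 3 the estimated value is 50 ug/mL with an expected range from 15 ug/mL to 100 ug/mL in this measurement.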

Compound 3, solubility: 50 ug/mL
Estimate against measurement, compound 3: no gap at the digits printed; the measured number falls inside the stated range.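

In this assay, 4-aminobutoxy in place of (4-aminopiperidin-1-yl)sulfonyl on the aromatic carbon, para to a large group, gives a 4.0-fold higher number from compound 2 to compound 3 (0.60 log units; beyond the scatter), so this position now has a measured step with an exact size at both ends and a side group with no ring. With the oxygen link kept, 4-aminobutyl in place of piperidin-4-yl gives an at least 2.0-fold lower number from compound 1 to compound 3 (0.30 log units; that floor lies within the scatter), so the open chain and the ring cannot be put in order on this reading. Compound 1 stands at a limit, not a number, which leaves that step open at one end: the limit of > 100 ug/mL in this assay, at which 1 of the 3 values shown sits.

The step to the 4-aminobutoxy group removes the sulfonyl and the ring together, so the series does not yet show which of the two changes carries the difference. A sulfonyl bearing an open-chain amine, a longer chain on the oxygen, or a carboxylic acid in place of the amine on the chain would separate these parts.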